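A few compounds are considered here, and "the series" means these few. Any claim that something is new, unique, unknown or untested is made for them only; others in the source may bear on it.

Of the compounds shown here, three sharing one core have been measured in an ADME assay on AGS cells (Homo sapiens) for cytotoxicity, read by neutral red uptake, with a stated time of 24 h; a higher number here means a weaker inhibitor, a lower number a stronger inhibitor: compound 1 `CC(=O)Oc1c(C(C)C)cc2c3c1OC(=O)[C@@]31CCCC(C)(C)[C@@H]1CC2` gives 275000 nM, compound 2 `CC(C)c1cc2c3c(c1OC(=O)CCl)OC(=O)[C@@]31CCCC(C)(C)[C@@H]1CC2` gives 103000 nM, and compound 3 `CCC(=O)Oc1c(C(C)C)cc2c3c1OC(=O)[C@@]31CCCC(C)(C)[C@@H]1CC2` gives 113000 nM. Compound 3 therefore sits well under compound 1, and the closest comparison shows a 1.1-fold higher number from compound 2 to compound 3 (0.04 log units; within the scatter). The next compound, compound 4 `CCCC(=O)Oc1c(C(C)C)cc2c3c1OC(=O)[C@@]31CCCC(C)(C)[C@@H]1CC2`, brings one change: methyl in place of hydrogen on a saturated chain carbon, two bonds along the chain from a carbonyl carbon, with methyl in place of hydrogen on a saturated chain carbon, two bonds along the chain from a carbonyl carbon. Within the data shown here, the nearest precedent is the same swap on a saturated chain carbon bound to a carbonyl carbon, which gave a 2.4-fold lower number from compound 1 to compound 3 (0.39 log units; beyond the scatter), a modest step. Among the measured compounds shown here, that is only one step, and it sits at a different place on the chain, so a smaller move toward a lower number is expected, possibly none beyond the scatter. The expected change is a 1.3-fold lower number from compound 3 to compound 4 (0.12 log units; within the scatter). For compound 4 the estimated value is 85000 nM, with an expected range from 42000 nM to 170000 nM.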

Compound 4, half-maximal inhibitory concentration: 99500 nM
Estimate against measurement, compound 4: 1.2-fold (0.07 log units) below; measured number inside the range.
By their numbers in this assay, from the lowest: compounds 4, 2 and 3 (each within the scatter of the next); then compound 1.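

In this assay, methyl in place of hydrogen on a saturated chain carbon, two bonds along the chain from a carbonyl carbon, gives a 1.1-fold lower number from compound 3 to compound 4 (0.06 log units; within the scatter), so this swap shows no readable change here, whereas the same swap on a saturated chain carbon bound to a carbonyl carbon gave a 2.4-fold lower number from compound 1 to compound 3 (0.39 log units; beyond the scatter). Ethyl in place of chloro on that nearer carbon also shows no readable change, at a 1.0-fold lower number from compound 2 to compound 4 (0.02 log units; within the scatter), while ethyl in place of hydrogen there gives a 2.8-fold lower number from compound 1 to compound 4 (0.44 log units; beyond the scatter), so compound 1 alone stands apart from the other three. Nothing shown here gives a cause for these steps.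

Going by these compounds, it remains open whether a longer chain would stay level with compound 4 or move away from it. An amine or a carboxylic acid at the end of the chain is also untested among the compounds shown.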